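Chloro on the shared core of compound 3

This account rests on a few compounds, and the source may have more. Where it says the series, first, only, none or still open, it means among the compounds named here.

Values in a functional assay on MCF7 cells (Homo sapiens) (on this read-out lower numbers stand for stronger inhibition of growth and higher numbers for weaker inhibition of growth), so far are these:
- compound 1 `N#Cc1ccc(/C=C/S(=O)(=O)Cc2ccc(Nc3ncnc4ccccc34)cc2)cc1` (> 100000 nM), a limit of the assay and not a number
- compound 2 `O=S(=O)(/C=C/c1ccc(Cl)cc1)Cc1ccc(Nc2ncnc3ccccc23)cc1` (52000 nM)
- compound 3 `O=S(=O)(/C=C/c1ccc(C(F)(F)F)cc1F)Cc1ccc(Nc2ncnc3ccccc23)cc1` (100000 nM)

Compound 3 (100000 nM) stands level with compound 2 (52000 nM). The gap is a 1.9-fold higher number from compound 2 to compound 3 (0.28 log units; within the scatter) and no order is read from it.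

The next compound is compound 4 `O=S(=O)(/C=C/c1ccc(C(F)(F)F)cc1F)Cc1ccc(Nc2ncnc3cc(Cl)ccc23)cc1` and the change is chloro in place of hydrogen on an aromatic carbon in the core, which is chloro in place of hydrogen on an aromatic carbon, quinazolin-4-yl becoming 7-chloroquinazolin-4-yl.

Among the measured compounds shown here, no measured step makes this change at this place. The closest in kind is an at least 1.9-fold lower number from compound 1 to compound 2 (0.28 log units; that floor lies within the scatter) and it puts chloro in place of cyano, on a different ring. The step of a number no higher from compound 1 to compound 3 (the limit leaves the size open) leaves its size open. The series therefore offers only small readable steps, such as a 1.9-fold higher number from compound 2 to compound 3 (0.28 log units; within the scatter) in the aryl group, and no step beyond the scatter is expected in this assay here. The expected step is a 1.4-fold lower number from compound 3 to compound 4 (0.15 log units; within the scatter) and its direction is not firmly expected either way. Compound 4 could also come back only as a limit, the limit of > 100000 nM in this assay, at which 1 of the 3 values shown sits, being the one seen so far. For compound 4 the estimate is 70000 nM (expected range 25000 nM to 150000 nM).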

Compound 4, concentration for 50% growth inhibition: > 100000 nM
Compound 4 ended at the assay's limit; the forecaster's own chance of this, stated with the estimate: 35%; middle value at least 1.4-fold (0.15 log units) away from the limit.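

Compound 4 sits at a limit of the assay, not at a number. In this assay, among the compounds shown here, chloro in place of hydrogen on an aromatic carbon of the shared core gives a number no lower from compound 3 to compound 4 (the limit leaves the size open), which adds one thing the earlier steps in the aryl group did not show: this first change on the core brings no lower number, so chloro here opens no visible route to stronger inhibition of growth. With compound 3 already at the top of the readable values, the series now presses against the ceiling of this read-out, and further weak compounds may separate poorly: the limit of > 100000 nM in this assay, at which 2 of the 4 values shown sit.

The compounds shown leave open whether any other group on this carbon of the core, such as an amine or a methoxy group, would bring the number in this assay down into the readable range. They also leave open how chloro on the core behaves with 4-chlorophenyl as the aryl group, the group of compound 2, which gives a readable 52000 nM.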